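Replacing octyl with cyclopentyl in compound 3

The compounds below may be only part of what the source reports. "The series", "measured", "known", "first", "only" and "open" are said of these compounds alone.

Compound 1 `CCCC(=O)Nc1ccn([C@@H]2CO[C@H](CO)O2)c(=O)n1` gives 8070 nM
Compound 2 `CCCCC(=O)Nc1ccn([C@@H]2CO[C@H](CO)O2)c(=O)n1` gives 9130 nM
Compound 3 `CCCCCCCCC(=O)Nc1ccn([C@@H]2CO[C@H](CO)O2)c(=O)n1` gives 276 nM

In a functional assay on SW1573 cells (Homo sapiens) for cytotoxicity, read by sulforhodamine B assay, with a stated time of 72 h (a lower number here means a stronger inhibitor, a higher number a weaker inhibitor), compound 3 stands lowest of the three at 276 nM and is the strongest inhibitor here. Compound 4 `O=C(Nc1ccn([C@@H]2CO[C@H](CO)O2)c(=O)n1)C1CCCC1` is not yet measured and differs through cyclopentyl in place of octyl on a carbonyl carbon with cyclopentyl in place of octyl on a carbonyl carbon. Two measured steps were large (a 29-fold lower number from compound 1 to compound 3 (1.47 log units; beyond the scatter) and a 33-fold lower number from compound 2 to compound 3 (1.52 log units; beyond the scatter)) while a third stayed within the scatter (a 1.1-fold higher number from compound 1 to compound 2 (0.05 log units; within the scatter)). For the measured compounds named here, compound 4 lacks octyl, as do compound 1 and compound 2, yet no measured compound carries cyclopentyl. It is therefore expected to sit near those two. The step expected in this assay is large, toward a weaker inhibitor (a 25-fold higher number from compound 3 to compound 4 (1.40 log units; beyond the scatter)). Compound 4 is estimated at 7000 nM (expected range 2500 nM to 20000 nM).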

Compound 4, half-maximal inhibitory concentration: 8800 nM
Compound 4: the middle estimate sits 1.3-fold (0.10 log units) below what was measured; low and high end bracket the measured number.
By their numbers in this assay, from the lowest: compound 3; then compounds 1, 4 and 2 (each within the scatter of the next).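

In this assay, putting cyclopentyl in place of octyl on the carbonyl carbon loses nearly all of the octyl compound's strength (a 32-fold higher number from compound 3 to compound 4 (1.50 log units; beyond the scatter)). Cyclopentyl instead matches the short chains, butyl (a 1.0-fold lower number from compound 2 to compound 4 (0.02 log units; within the scatter)) and propyl (a 1.1-fold higher number from compound 1 to compound 4 (0.04 log units; within the scatter)), both steps within the scatter. Carbon ring or short chain, these groups give the same result here, and only octyl stands apart.

On these data alone, whether a hexyl group or a chain longer than octyl would keep that strength remains open. No evidence is available to explain the octyl result.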